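One More Chain Carbon in Two Related Series

The source may hold more compounds than are shown below. What is called first, only, known or untested is meant among the compounds shown, and "the series" means these compounds.

Compound 1 `CN(C)C(=O)c1cc2cnc(Nc3ccc(C(=O)NCCCCCCN=C=S)cc3)nc2n1C1CCCC1` and compound 2 `CN(C)C(=O)c1cc2cnc(Nc3ccc(C(=O)NCCCCCCCN=C=S)cc3)nc2n1C1CCCC1` share one core and differ only by a group of 4 heavy atoms (2 carbon, 1 nitrogen, 1 sulfur; no ring) in place of a group of 3 heavy atoms (1 carbon, 1 nitrogen, 1 sulfur; no ring), on a saturated chain carbon, six bonds along the chain from an amide-type nitrogen. In a functional assay on NCI-H1299 cells (Homo sapiens) for inhibition, read by CCK-8 assay, with a stated time of 72 h, tested at 1 uM (on this read-out higher numbers stand for a stronger effect at the one concentration tested and lower numbers for a weaker effect), compound 1 gives 49.4%, and compound 2 gives 75.7%, a step of a number 26.3 percentage points higher from compound 1 to compound 2 (beyond the scatter). Compound 3 `CN(C)C(=O)c1cc2cnc(Nc3ccc(C(=O)NCCCCN=C=S)cc3O)nc2n1C1CCCC1` rests on a different core; the difference between the two cores is not broken down here. In this assay compound 3 gives 10.7%, the lowest of the three numbers. Compound 4 `CN(C)C(=O)c1cc2cnc(Nc3ccc(C(=O)NCCCCCN=C=S)cc3O)nc2n1C1CCCC1` differs from compound 3 by a group of 4 heavy atoms (2 carbon, 1 nitrogen, 1 sulfur; no ring) in place of a group of 3 heavy atoms (1 carbon, 1 nitrogen, 1 sulfur; no ring), on a saturated chain carbon, four bonds along the chain from an amide-type nitrogen, the same kind of change as between compound 1 and compound 2, though here it sits four bonds along the chain from an amide-type nitrogen rather than six. Resting on the earlier step of a number 26.3 percentage points higher from compound 1 to compound 2 (beyond the scatter), a rise of similar size is expected, a number 17.3 percentage points higher from compound 3 to compound 4 (beyond the scatter), with some caution since the starting number is low. Compound 4 is therefore estimated at 28%, with a range from 8% to 52%.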

Compound 4, a percentage reported as inhibition, at one concentration (the size of the read-out at that concentration, not a potency): 22.6%
Compound 4: middle estimate off by 5.4 percentage points, on the high side, and the stated range covers the measured number.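

In this assay, adding one chain carbon again goes with a higher number on the second core, a number 11.9 percentage points higher from compound 3 to compound 4 (beyond the scatter), so the direction of the change is the same on both cores. The size of the step does not carry over unchanged: the same change on two cores in this assay, a number 26.3 percentage points higher (beyond the scatter) from compound 1 to compound 2 and a number 11.9 percentage points higher (beyond the scatter) from compound 3 to compound 4, 14.4 percentage points apart, beyond the scatter of two such steps These two pairs do not show why the steps differ in size, and they cannot separate the effect of the core from that of the starting chain length, nor do they set a rule for the whole series.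

From the compounds shown here alone, it remains open whether a longer chain on the core of compound 4 would raise the number further. Going by these compounds, it is also open how an amine in place of the sulfur-bearing group would read.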